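Propyl to isopropyl on sulfur: estimating compound 4

This account rests on a few compounds, and the source may have more. Where it says the series, first, only, none or still open, it means among the compounds named here.

Going by the values given here, compound 3 `CCCSC1=N[C@@H](C(=O)OC)[C@@H]2C(=O)N(c3ccccc3)C(=O)[C@H]12` gives 86% in a functional assay for inhibition, tested at 100 uM (a higher number here means more inhibition at the concentration tested (going by the name of the read-out), a lower number less inhibition), the highest of the three numbers measured so far, though its gap to compound 1 `CCCCSC1=N[C@@H](C(=O)OC)[C@@H]2C(=O)N(c3ccccc3)C(=O)[C@H]12`, which gives 82%, lies within the scatter. Compound 2 `COC(=O)[C@H]1N=C(SC(C)C)[C@H]2C(=O)N(c3ccccc3)C(=O)[C@H]21` gives 72% in this assay, a number beyond the scatter below compound 3.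

Compound 4 `COC(=O)[C@@H]1N=C(SC(C)C)[C@H]2C(=O)N(c3ccccc3)C(=O)[C@H]21` differs from compound 3 by isopropyl in place of propyl on a sulfur. Among the compounds with values here, the only measured single-change step touching the chain on sulfur, a number 4 percentage points higher from compound 1 to compound 3 (within the scatter), is within the scatter. Within the data shown here, compound 2, which also carries isopropyl on sulfur, sits lower than compound 3, but no single-change step connects compound 2 to compound 4. The expected step of a number 10 percentage points lower from compound 3 to compound 4 (within the scatter) is therefore a modest decrease, close to the edge of the scatter. Compound 4 is estimated at 76%, with a range from 62% to 88%.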

Compound 4, a percentage reported as inhibition, at one concentration (the size of the read-out at that concentration, not a potency): 89%
Beside the measured number, compound 4's estimate is 13 percentage points below it; the whole stated range lies below it.
By their numbers in this assay, from the lowest: compounds 2, 1, 3 and 4 (each within the scatter of the next, the first and the last beyond it).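

In this assay, changing the chain on sulfur does not move the number beyond the scatter: a number 3 percentage points higher from compound 3 to compound 4 (within the scatter), and a number 7 percentage points higher from compound 1 to compound 4 (within the scatter). Isopropyl alone therefore does not account for the lower number of compound 2. Instead, a number 17 percentage points higher from compound 2 to compound 4 (beyond the scatter), so this gap goes with configuration as drawn rather than with the chain on sulfur: the fact that compounds 2 and 4 differ only in the configuration as drawn

Open, on these data alone, is whether the same configurational gap appears with propyl or butyl on sulfur. Also open, as far as these compounds go, is whether a chain ending in an amine or a carboxylic acid keeps this level of inhibition.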